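The source may hold more compounds than are shown below. What is called first, only, known or untested is meant among the compounds shown, and "the series" means these compounds.

Measured compounds:
Compound 1 `ClCc1ccccc1Cn1cnc2c(Cl)nc(Cl)nc21` — 4670 nM in a functional assay on A549 cells (Homo sapiens) for cytotoxicity, read by sulforhodamine B assay, with a stated time of 48 h; a higher number here means a weaker inhibitor of growth, a lower number a stronger inhibitor of growth.
Compound 2 `ClCc1ccccc1Cn1cnc2c(Cl)ncnc21` — 25700 nM.
Compound 3 `ClCc1ccccc1Cn1cnc2ncnc(Cl)c21` — 24000 nM.

Compound 1 and compound 2 differ in one place: chloro in place of hydrogen on an aromatic carbon. That change made a 5.5-fold lower number from compound 2 to compound 1 (0.74 log units; beyond the scatter). Compound 3 has the same atoms as compound 2 joined differently; the difference between the two cores is not broken down here. Compound 3 and compound 2 lie within the scatter of each other, so no order between them is claimed. Compound 4 `ClCc1ccccc1Cn1cnc2nc(Cl)nc(Cl)c21` is yet to be measured and differs from compound 3 by chloro in place of hydrogen on an aromatic carbon, the same change, with the same surroundings word for word. In this assay the step from compound 3 to compound 4 is expected to be a 5.5-fold lower number from compound 3 to compound 4 (0.74 log units; beyond the scatter), close beside the earlier step, because the same change gave a 5.5-fold lower number from compound 2 to compound 1 (0.74 log units; beyond the scatter) on the core of compound 2. Compound 4 is therefore estimated at 4400 nM, likely between 1800 nM and 11000 nM.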

Compound 4, concentration for total growth inhibition: 5750 nM
Compound 4: the middle estimate sits 1.3-fold (0.12 log units) below what was measured, within the range that was stated.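

In this assay, chloro in place of hydrogen on an aromatic carbon gave a 4.2-fold lower number from compound 3 to compound 4 (0.62 log units; beyond the scatter), and this step stands close to the earlier one on the other core: the same change on two cores in this assay, a 5.5-fold lower number (0.74 log units; beyond the scatter) from compound 2 to compound 1 and a 4.2-fold lower number (0.62 log units; beyond the scatter) from compound 3 to compound 4, 1.3-fold (0.12 log units) apart, within the scatter of two such steps. The change therefore carried over from the core of compound 2 to the core of compound 3 with its size kept. Within the data shown here, this rests on only two closely related cores in one cell assay, so it does not show why the step has this size or that it would hold on any other core.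

The compounds shown leave open whether an amine or a methoxy group in place of that chloro would give a similar step. They also leave open what a methyl group in place of the chloromethyl group would do.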